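This account rests on a few compounds, and the source may have more. Where it says the series, first, only, none or still open, it means among the compounds named here.

Compound 3 `COc1cc2c(Oc3ccc(NC(=O)c4cn(-c5ccc(F)c(F)c5)nn4)cc3F)ccnc2cc1OCCCN1CCC(C)CC1` belongs to a small series built on a shared core, of which compound 1 `COc1cc2c(Oc3ccc(NC(=O)c4cn(-c5ccccc5F)nn4)cc3F)ccnc2cc1OCCCN1CCC(C)CC1` and compound 2 `COc1cc2c(Oc3ccc(NC(=O)c4cn(-c5ccccc5C)nn4)cc3F)ccnc2cc1OCCCN1CCC(C)CC1` are the other members. In a functional assay on MKN-45 cells (Homo sapiens) for cytotoxicity, read by MTT assay, with a stated time of 72 h (on this read-out lower numbers stand for stronger inhibition and higher numbers for weaker inhibition), compound 1 gives 130 nM. In this assay compound 2 gives "not determined" (no result reported), that is, no result was reported for it. In this assay, among the compounds with values here, compound 3 gives 1290 nM, which is the higher of the two numbers available; the step of a 9.9-fold higher number from compound 1 to compound 3 (1.00 log units; beyond the scatter) is the only measured step in the set and separates compound 3 from compound 1 by a margin beyond the scatter.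

Compound 4 `COc1cc2c(Oc3ccc(NC(=O)c4cn(-c5ccc(F)c(F)c5)nn4)cc3F)ccnc2cc1OCCCN1CCN(C)CC1` is derived from compound 3 by a single change: 4-methylpiperazin-1-yl in place of 4-methylpiperidin-1-yl on a saturated chain carbon, three bonds along the chain from an oxygen on an aromatic ring. The aromatic parts of compound 3 are carried over unchanged. Within the data shown here, no measured step touches the chain amine; the one step that exists, from compound 1 to compound 3, concerns the aryl group on the triazole nitrogen and gives no guidance on the amine. With nothing to indicate a direction, the step of a 1.0-fold higher number from compound 3 to compound 4 (0.00 log units; within the scatter) from compound 3 to compound 4 is expected to stay within the scatter, though with low confidence. In this assay compound 4 is therefore estimated at 1300 nM, with a range from 400 nM to 4000 nM.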

Compound 4, half-maximal inhibitory concentration: 160 nM
Estimate against measurement, compound 4: 8.1-fold (0.91 log units) above; the whole stated range lies above it.
By their numbers in this assay, from the lowest: compounds 1 and 4 (each within the scatter of the next); then compound 3.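

In this assay this position on the chain proves responsive to a small exchange: the step of an 8.1-fold lower number from compound 3 to compound 4 (0.91 log units; beyond the scatter) comes with 4-methylpiperazin-1-yl in place of 4-methylpiperidin-1-yl and lies beyond the scatter, towards stronger inhibition. Within the data shown here, the earlier series held only the step of a 9.9-fold higher number from compound 1 to compound 3 (1.00 log units; beyond the scatter) in the aryl group on the triazole nitrogen, so this is the first view of the chain amine, and it shows that replacing one ring carbon by a nitrogen, with the number of heavy atoms unchanged, can move the read-out by a clear margin. Nothing available accounts for this step, and no measurement bears on the reason for it.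

The compounds shown leave open whether the same exchange gives a step of similar size with the 2-fluorophenyl group of compound 1, as the only pair carrying it has the 3,4-difluorophenyl group. They also leave open how a morpholine, a dimethylamino group or a longer chain carrying the 4-methylpiperazin-1-yl ring would read at this position.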